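A Carboxy Group on the Amide Side Chain

This account rests on a few compounds, and the source may have more. Where it says the series, first, only, none or still open, it means among the compounds named here.

Compound 1 `CNC(=O)Cn1nc(N)c2c(C(F)(F)F)cc(-c3ccccc3)nc21` is tested in a functional assay on A549 cells (Homo sapiens) for cytotoxicity, read by MTT assay, with a stated time of 24 h (on this read-out higher numbers stand for weaker inhibition and lower numbers for stronger inhibition), where compound 1 gives 15300 nM. Compound 2 `Nc1nn(CC(=O)NCc2ccccc2)c2nc(-c3ccccc3)cc(C(F)(F)F)c12` gives 17300 nM in this assay; these two numbers lie within the usual scatter of each other, so compound 1 does not stand apart. Compound 3 `Nc1nn(CC(=O)NCC(=O)O)c2nc(-c3ccccc3)cc(C(F)(F)F)c12` carries carboxy in place of hydrogen on a saturated chain carbon bound to an amide-type nitrogen. Among the compounds with values here, the only comparable step is a 1.1-fold higher number from compound 1 to compound 2 (0.05 log units; within the scatter), at the same place, which gives no reason to expect a change beyond the scatter. So for compound 3 a step of about a 1.1-fold higher number from compound 1 to compound 3 (0.05 log units; within the scatter) is expected. In this assay compound 3 is estimated at 17000 nM, expected to fall between 6000 nM and 50000 nM.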

Compound 3, half-maximal inhibitory concentration: 19900 nM
For compound 3 the middle estimate is 1.2-fold (0.07 log units) below the measured one, and the stated range covers the measured number.
By their numbers in this assay, from the lowest: compounds 1, 2 and 3 (each within the scatter of the next).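

With a 1.3-fold higher number from compound 1 to compound 3 (0.11 log units; within the scatter) and a 1.2-fold higher number from compound 2 to compound 3 (0.06 log units; within the scatter) in this assay, adding a carboxy group on the saturated chain carbon bound to the amide-type nitrogen leaves the result within the scatter of both earlier compounds. Hydrogen, phenyl and carboxy at this place therefore cannot be told apart here, which the single phenyl step could not show. No supporting measurement is available to explain this result.

From the compounds shown here alone, whether an amine or a longer chain carrying the carboxy group at this place would move the number beyond the scatter remains open.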